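This account rests on a few compounds, and the source may have more. Where it says the series, first, only, none or still open, it means among the compounds named here.

Within the data shown here, in a physicochemical assay, with a stated time of 6 min (on this read-out lower numbers stand for stronger inhibition and higher numbers for weaker inhibition), compound 1 (`COc1ccc(NC(=O)Nc2nc(-c3cc4cc([N+](=O)[O-])ccc4o3)cs2)cc1`) gives 121000 nM as the higher of the two numbers so far. Compound 2 (`COc1cccc(NC(=O)Nc2nc(-c3cc4ccccc4o3)cs2)c1`) gives 200 nM on the same read-out, a far lower number and a gap well beyond the scatter. The two compounds differ in more than one place, however, so that gap belongs to no single change.

Compound 3 (`COc1ccc(NC(=O)Nc2nc(-c3cc4cc(Br)ccc4o3)cs2)cc1`) has not yet been measured. It departs from compound 1 at one place, with bromo in place of nitro on an aromatic carbon. Among the measured compounds shown here, no measured pair shows this change alone, so its size in this assay can only be estimated, and the uncertainty is wide. Compound 2, which carries neither nitro nor bromo, sits at 200 nM on this scale, so a move toward a lower number, beyond the scatter, is expected. The estimated step is a large one (a 40-fold lower number from compound 1 to compound 3 (1.61 log units; beyond the scatter)). For compound 3 the expected value is 3000 nM as a middle figure (estimated range 300 nM to 40000 nM).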

Compound 3, half-maximal inhibitory concentration: > 200000 nM
Compound 3 was reported as a limit; the forecaster's own chance of this, stated with the estimate: 10%; middle value at least 66-fold (1.82 log units) from the limit.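

In this assay compound 3 gives > 200000 nM, which is a limit of the assay and not a number. Among these compounds, this is the first view of a single change at this aromatic carbon of the six-membered aromatic ring, and bromo in place of nitro gives an at least 1.6-fold higher number from compound 1 to compound 3 (0.21 log units; that floor lies within the scatter), so the exchange brings no measured move toward a lower number, while the floor of the step does not clear the usual scatter. The real size and direction of the step remain unread because compound 3 is held only by a limit: the limit of > 200000 nM in this assay, at which 1 of the 3 values shown sits.

The compounds shown leave open how an amine or a carboxylic acid on this same aromatic carbon would read in the core of compound 1, and whether any group there would give a number that can be compared directly with that of compound 1. They also leave unassigned the large gap between compound 1 and compound 2, as no single change yet connects those two compounds.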